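The compounds below may be only part of what the source reports. "The series", "measured", "known", "first", "only" and "open" are said of these compounds alone.

Compound 3 `Cc1ccc(C(=O)Nc2nc(-c3ccccc3)cn3cc(-c4ccccc4)nc23)cc1` stands lowest of the three compounds measured in an assay on cells for displacement of a labelled ligand from adenosine receptor A1 (Homo sapiens), read by scintillation counting, with a stated time of 120 min, tested at 1 uM; a lower number here means less inhibition, a higher number more inhibition at the concentration tested (going by the name of the read-out): compound 3 gives 1%, while compound 1 `Nc1nccn2cc(-c3ccco3)nc12` gives 21% and compound 2 `Cc1ccc(C(=O)Nc2nccn3cc(-c4ccccc4)nc23)cc1` gives 26%. Among the compounds with values here, the only step between measured compounds that differ in a single place runs a number 25 percentage points lower from compound 2 to compound 3 (beyond the scatter), and that step concerns a substituent on the shared core, not the group on the carbonyl carbon. Compound 4 `O=C(Nc1nc(-c2ccccc2)cn2cc(-c3ccccc3)nc12)c1cccs1` differs from compound 3 in one place: thiophen-2-yl in place of 4-methylphenyl on a carbonyl carbon. Within the data shown here, no measured step bears directly on this change; the exchange of a 4-methylphenyl for a thiophen-2-yl on the carbonyl carbon has no counterpart among the three measured compounds, so nothing here argues for a shift in either direction. The expectation for compound 4 is therefore a step of no size beyond the scatter, a number 4 percentage points higher from compound 3 to compound 4 (within the scatter). Compound 4 is estimated at 5%, with a range from -10% to 20%.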

Compound 4, a percentage reported as inhibition, at one concentration (the size of the read-out at that concentration, not a potency): 5%
Estimate against measurement, compound 4: no gap at the digits printed, and the stated range covers the measured number.
By their numbers in this assay, from the lowest: compounds 3 and 4 (each within the scatter of the next); then compounds 1 and 2 (each within the scatter of the next).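

In this assay, within the data shown here, the exchange of 4-methylphenyl for thiophen-2-yl on a carbonyl carbon gives a number 4 percentage points higher from compound 3 to compound 4 (within the scatter), the first reading at this place, as the earlier step concerned a substituent on the shared core. With the phenyl of compound 3 kept on the core, the two rings on the carbonyl carbon are not told apart here, though with compound 3 at 1% and compound 4 at 5%, the read-out leaves little room to see any further loss. Nothing measured here gives a reason for this result.

On these data alone, whether the same exchange would read alike on compound 2, which lacks that phenyl, stays open. Also open, as far as these compounds go, is how an amine, a carboxylic acid or a longer alkyl chain on the carbonyl carbon would read in this assay.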